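Swapping the ring group on the carbonyl carbon

The compounds below may be only part of what the source reports. "The series", "measured", "known", "first", "only" and "open" are said of these compounds alone.

Compound 1 `Cc1nc(S(C)(=O)=O)ccc1Oc1ncnc(OC2CCN(C(=O)OC(C)(C)CF)CC2)c1F` gives 95% in a functional assay on isolated protein for inhibition of Glucose-dependent insulinotropic receptor (Rattus norvegicus), read by HTRF and cAMP accumulation; a higher number here means a larger maximal response, a lower number a smaller maximal response. Compound 2 `Cc1nc(S(C)(=O)=O)ccc1Oc1ncnc(OC2CCN(C(=O)SC3CC3)CC2)c1F` gives 80% in this assay. Among the measured compounds shown here, the single measured step is a number 15 percentage points lower from compound 1 to compound 2 (beyond the scatter), a change of the group on the carbonyl carbon. For the measured compounds named here, compound 2 therefore stands at the lower of the two numbers known so far, with compound 1 higher by an amount beyond the scatter.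

Compound 3 `Cc1nc(S(C)(=O)=O)ccc1Oc1ncnc(OC2CCN(C(=O)C(C)(C)F)CC2)c1F` has not yet been measured. The change from compound 2 to compound 3 is a group of 4 heavy atoms (3 carbon, 1 fluorine; no ring) in place of a group of 4 heavy atoms (3 carbon, 1 sulfur; one three-membered non-aromatic ring of carbon only), on a carbonyl carbon. Going by the values given here, the only step that bears on it is a number 15 percentage points lower from compound 1 to compound 2 (beyond the scatter), in which a non-ring group containing fluorine gave way to the sulfur-containing three-membered ring group on the same carbonyl carbon and the response fell. Compound 3 goes back to a non-ring group containing fluorine, now of 4 heavy atoms rather than 6. An upward step in this assay is expected, roughly the size of the earlier loss, estimated as a number 10 percentage points higher from compound 2 to compound 3 (within the scatter). The estimate for compound 3 is 90%, with a range from 76% to 102%. Two compounds form a thin basis, so the range is kept wide.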

Compound 3, largest response reached (reported as efficacy), in percent of the reference or control that the assay uses: 74%
Compound 3: middle estimate off by 16 percentage points, on the high side, outside the stated range (below it).
By their numbers in this assay, from the lowest: compounds 3 and 2 (each within the scatter of the next); then compound 1.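

In this assay, replacing the sulfur-containing three-membered ring group with 1-fluoro-1-methylethyl, on a carbonyl carbon whose other neighbour is an amide-type nitrogen in a ring, gives a number 6 percentage points lower from compound 2 to compound 3 (within the scatter), so this position does not separate these two groups, and a fluorine-bearing non-ring group alone does not match the response of compound 1. The step from the larger oxygen-containing group gives a number 21 percentage points lower from compound 1 to compound 3 (beyond the scatter), which leaves compound 1 apart from both others, though this change alters oxygen content and heavy-atom count at once and the two effects cannot be separated. No measurement at hand accounts for either step.

Open, going by these compounds, is whether the oxygen or the fluorine matters more, which a tert-butoxy group on the same carbonyl carbon, keeping the oxygen without the fluorine, or a plain 1-methylethyl group would help to settle. Also open, on these data alone, is how a cyclopropyl group joined directly to the carbonyl carbon, without the sulfur, would compare with the sulfur-containing three-membered ring group.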